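Cell tolerance from compound 3 to compound 4

A few compounds are considered here, and "the series" means these few. Any claim that something is new, unique, unknown or untested is made for them only; others in the source may bear on it.

Measured in an ADME assay on L929 cells (Mus musculus) for cytotoxicity, read by resazurin assay, with a stated time of 48 h; a lower number here means that less compound is tolerated, a higher number that more compound is tolerated:
- Compound 1 `C=CCn1c2ccc([N+](=O)[O-])cc2c(=O)n1Cc1ccccc1`: 192000 nM
- Compound 2 `C#CCn1c2ccc([N+](=O)[O-])cc2c(=O)n1Cc1ccccc1`: 195000 nM
- Compound 3 `COC(=O)CCn1c2ccc([N+](=O)[O-])cc2c(=O)n1Cc1ccccc1`: > 256000 nM, a limit and not a number

Compound 3 stands at the limit of > 256000 nM in this assay, at which 1 of the 3 values shown sits. Compound 4 `CCOC(=O)CCCn1c2ccc([N+](=O)[O-])cc2c(=O)n1Cc1ccccc1` carries (ethoxycarbonyl)methyl in place of methoxycarbonyl on a saturated chain carbon, two bonds along the chain from an aromatic nitrogen. Among the compounds with values here, three measured steps concern this same chain: a 1.0-fold higher number from compound 1 to compound 2 (0.01 log units; within the scatter), an at least 1.3-fold higher number from compound 1 to compound 3 (0.12 log units; that floor lies within the scatter) and an at least 1.3-fold higher number from compound 2 to compound 3 (0.11 log units; that floor lies within the scatter). All three lie within the scatter, so the expectation in this assay is no step beyond it. The estimated step is an at least 1.0-fold lower number from compound 3 to compound 4 (0.01 log units; that floor lies within the scatter). For compound 4 the expected value is 250000 nM, with an estimated range from 140000 nM to 420000 nM.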

Compound 4, concentration lethal to 50% of the cells: 78100 nM
Estimate against measurement, compound 4: 3.2-fold (0.51 log units) above; the measured number lies below the stated range.
By their numbers in this assay, from the lowest: compound 4; then compounds 1 and 2 (each within the scatter of the next). At a limit, above all of these: compound 3.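

Earlier changes on this chain stayed within the scatter in this assay, but 3-(ethoxycarbonyl)propyl gives clear steps: a 2.5-fold lower number from compound 2 to compound 4 (0.40 log units; beyond the scatter) and a 2.5-fold lower number from compound 1 to compound 4 (0.39 log units; beyond the scatter). Against the 2-(methoxycarbonyl)ethyl chain, the change gives an at least 3.2-fold lower number from compound 3 to compound 4 (0.51 log units; beyond the scatter), so this position can affect tolerance when the chain and its ester end change together. That step starts from a limit and not a number, the one for compound 3: the limit of > 256000 nM in this assay, at which 1 of the 4 values shown sits.

The compounds shown do not separate the longer chain from the ethyl ester, as a 2-(ethoxycarbonyl)ethyl or 3-(methoxycarbonyl)propyl group could. They also leave open how a carboxylic acid in place of the ester would behave.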